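The source may report more compounds than this note shows. Statements on the series, on what has been measured and on what is new or still open speak of the compounds shown alone.

In a functional assay on T47D cells (Homo sapiens) for cytotoxicity, read by sulforhodamine B assay, with a stated time of 48 h, tested at 100 uM (a higher number here means a weaker effect of the compound at the concentration tested, a lower number a stronger effect), compound 2 `COc1ccc(C(=O)/C=C/c2cc(-c3cc(OC)c(OC)c(OC)c3)n[nH]2)cc1OC` gives -46%, the second highest of three numbers. Compound 1 `COc1cc(-c2cc(/C=C/C(=O)c3ccc(N)cc3)[nH]n2)cc(OC)c1OC` gives -47%, within the scatter of compound 2, while compound 3 `COc1cc(-c2cc(/C=C/C(=O)c3ccc(F)c(F)c3)[nH]n2)cc(OC)c1OC` gives -11%, a much weaker effect, as the step of a number 35 percentage points higher from compound 2 to compound 3 (beyond the scatter) shows. Compound 4 `COc1cc(C(=O)/C=C/c2cc(-c3cc(OC)c(OC)c(OC)c3)n[nH]2)cc(OC)c1OC` has not yet been measured. The change is methoxy in place of hydrogen on an aromatic carbon: a methoxy group enters where a hydrogen stood, ortho to a methoxy group and meta to a large group. Among the compounds with values here, no measured step adds a group in this way; the known steps exchange the whole ring on the carbonyl carbon, a number 1 percentage points higher from compound 1 to compound 2 (within the scatter) and a number 36 percentage points higher from compound 1 to compound 3 (beyond the scatter), and give little guidance. The expected step is a number 6 percentage points higher from compound 2 to compound 4 (within the scatter), within the scatter. Compound 4 is therefore estimated at -40%, between -65% and -10%.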

Compound 4, a percentage reported as activity, at one concentration (the size of the read-out at that concentration, not a potency): -92%
Beside the measured number, compound 4's estimate is 52 percentage points above it; the whole stated range lies above it.
By their numbers in this assay, from the lowest: compound 4; then compounds 1 and 2 (each within the scatter of the next); then compound 3.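

In this assay a single methoxy group entering in place of a hydrogen gives a stronger effect, with a number 46 percentage points lower from compound 2 to compound 4 (beyond the scatter) as the step, so this place on the ring, ortho to a methoxy group and meta to a large group, is sensitive to substitution. The earlier steps shown here exchanged the whole ring on the carbonyl carbon, whereas this one shows that a small addition to an otherwise unchanged ring can also produce a large step.

As far as these compounds go, whether an ethoxy or a hydroxy group at this same place would act like methoxy remains open. No available measurement gives a reason for the step.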